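A few compounds are considered here, and "the series" means these few. Any claim that something is new, unique, unknown or untested is made for them only; others in the source may bear on it.

Compound 2 `NCCCCCOc1ccc([C@H]2CC[C@]3(CC2)OOC2(O3)C3CC4CC(C3)CC2C4)cc1` was tested in an ADME assay on microsomes from liver (Homo sapiens) for metabolic stability, read by LC-MS, tested at 1 uM; a higher number here means faster removal of the compound, a lower number slower removal. Its reading there is a limit of the assay rather than a number, < 7 mL.min-1.g-1. Compound 1 `CC(C)(CN)Oc1ccc([C@H]2CC[C@]3(CC2)OOC2(O3)C3CC4CC(C3)CC2C4)cc1` also stops at a limit, < 7 mL.min-1.g-1. Compound 3 `CC1(C)CC(O)(COc2ccc([C@H]3CC[C@]4(CC3)OOC3(O4)C4CC5CC(C4)CC3C5)cc2)CC(C)(C)N1` gives 14 mL.min-1.g-1. The step of an at least 2.0-fold higher number from compound 1 to compound 3 (0.30 log units; that floor lies within the scatter) and the step of an at least 2.0-fold higher number from compound 2 to compound 3 (0.30 log units; that floor lies within the scatter) are the two readable ones, while the step that the two limits leave unreadable from compound 1 to compound 2 links the first two compounds. Notably, there is the limit of < 7 mL.min-1.g-1 in this assay, at which 2 of the 3 values shown sit. Compound 4 `NCCCCOc1ccc([C@H]2CC[C@]3(CC2)OOC2(O3)C3CC4CC(C3)CC2C4)cc1` differs from compound 2 by amino in place of aminomethyl on a saturated chain carbon, four bonds along the chain from an oxygen on an aromatic ring. Among the measured compounds shown here, none of the measured steps shortens the chain in this way, so no shift beyond the scatter is expected in this assay. Compound 4 is therefore expected to give 5 mL.min-1.g-1, between 2 mL.min-1.g-1 and 12 mL.min-1.g-1, which means an expected step that the limit leaves unreadable from compound 2 to compound 4.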

Compound 4, intrinsic clearance in microsomes: < 7 mL.min-1.g-1
Compound 4: a limit, no number; the forecaster's own chance of this, stated with the estimate: 65%; the middle value does not contradict the limit.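

In this assay compound 4 also gives a limit, not a number: < 7 mL.min-1.g-1. Shortening the amine chain therefore does not lift the reading to a measurable value, and the one readable new step is an at least 2.0-fold lower number from compound 3 to compound 4 (0.30 log units; that floor lies within the scatter). The steps joining compound 4 to compound 1 and compound 2 cannot be read, and the limit now holds most of the set: the limit of < 7 mL.min-1.g-1 in this assay, at which 3 of the 4 values shown sit.

On these data alone, how the chain length affects removal under that limit stays open. So does whether a carboxylic acid in place of the amine, or a tertiary amine at the chain end, would give a measurable reading.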